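Aryl ether variation on the oxime-ether series

The source may report more compounds than this note shows. Statements on the series, on what has been measured and on what is new or still open speak of the compounds shown alone.

Measured so far in a functional assay on HCT-116 cells (Homo sapiens) for inhibition, read by MTT assay, with a stated time of 48 h; on this read-out lower numbers stand for stronger inhibition and higher numbers for weaker inhibition:
Compound 1, `Cc1nnsc1CO/N=C/c1c(C)nn(C)c1Oc1cccc(F)c1`: compound 1 reaches only the assay limit, > 50000 nM, which is a limit and not a number.
Compound 2, `Cc1nnsc1CO/N=C/c1c(C)nn(C)c1Oc1ccc(I)cc1`: compound 2 gives 43800 nM.
Compound 3, `Cc1ccc(Oc2c(/C=N/OCc3snnc3C)c(C)nn2C)cc1`: compound 3 gives 13800 nM.

Compound 3 holds the lowest of the two actual numbers; its nearest neighbour is compound 2, and the step of a 3.2-fold lower number from compound 2 to compound 3 (0.50 log units; beyond the scatter) lies beyond the scatter. The step of an at least 3.6-fold lower number from compound 1 to compound 3 (0.55 log units; beyond the scatter) is given only as a floor, since compound 1 sits at the limit (the limit of > 50000 nM in this assay, at which 1 of the 3 values shown sits). The step of an at least 1.1-fold lower number from compound 1 to compound 2 (0.05 log units; that floor lies within the scatter) is likewise a floor and stays within the scatter.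

Compound 4, `Cc1nnsc1CO/N=C/c1c(C)nn(C)c1Oc1cccc(F)c1F`, is not yet measured. It differs from compound 3 by 2,3-difluorophenyl in place of 4-methylphenyl on an oxygen on an aromatic ring. For the measured compounds named here, two measured steps bear on this: replacing a 3-fluorophenyl with the 4-methylphenyl gave an at least 3.6-fold lower number from compound 1 to compound 3 (0.55 log units; beyond the scatter), and replacing iodo with methyl on the aromatic carbon gave a 3.2-fold lower number from compound 2 to compound 3 (0.50 log units; beyond the scatter). Both point to the 4-methylphenyl as the variant with the lower number, so returning to a fluorinated phenyl is expected to move the number back up in this assay, by a step of roughly the same size, with a real chance that only a limit is reported.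

Compound 4 is therefore estimated at 40000 nM, with a range from 15000 nM to 120000 nM. That estimate corresponds to an expected step of a 2.9-fold higher number from compound 3 to compound 4 (0.46 log units; beyond the scatter).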

Compound 4, half-maximal inhibitory concentration: 6560 nM
For compound 4 the middle estimate is 6.1-fold (0.79 log units) above the measured one; the whole stated range lies above it.
By their numbers in this assay, from the lowest: compound 4; then compound 3; then compound 2. At a limit, above all of these: compound 1.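

In this assay, the 2,3-difluorophenyl on the oxygen gives the lowest number in the set, with a 2.1-fold lower number from compound 3 to compound 4 (0.32 log units; beyond the scatter) and a 6.7-fold lower number from compound 2 to compound 4 (0.82 log units; beyond the scatter), so the 4-methylphenyl no longer marks the best aryl ether here and a fluorinated phenyl is not tied to weak inhibition. A single fluoro in place of hydrogen on an aromatic carbon gives an at least 7.6-fold lower number from compound 1 to compound 4 (0.88 log units; beyond the scatter), which places the two fluorinated compounds, compound 1 and compound 4, at opposite ends of the order and shows that this position responds to the pattern of fluoro groups rather than to their mere presence. Compound 1 stands at a limit and not at a number, so that step can be read only as a floor: the limit of > 50000 nM in this assay, at which 1 of the 4 values shown sits.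

The compounds shown do not separate the contribution of the added fluoro from any requirement for both fluoro groups together, and a 2-fluorophenyl would be the direct test of that. As far as these compounds go, how a phenyl carrying an amine or a carboxylic acid would read in this assay also stays open.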